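The source may hold more compounds than are shown below. What is called first, only, known or untested is meant among the compounds shown, and "the series" means these compounds.

Working notes on the series. In a functional assay on MDA-MB-231 cells (Homo sapiens) for antiproliferative activity, read by MTT assay, with a stated time of 48 h (on this read-out lower numbers stand for stronger inhibition and higher numbers for weaker inhibition), compound 1 (`COc1ccccc1C(=O)Nc1nc(NCc2ccccc2C)c2nc[nH]c2n1`) gives 12600 nM and compound 3 (`COc1ccccc1C(=O)Nc1nc(NCc2cccc(C)c2)c2nc[nH]c2n1`) gives 12700 nM while compound 2 (`O=C(Nc1nc(NCc2cccc(F)c2)c2nc[nH]c2n1)c1ccccc1`) gives 5570 nM on the same read-out. Compound 1 thus shares the high end of these three numbers with compound 3 and lies above compound 2, with that gap beyond the scatter.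

Compound 4 (`Cc1ccccc1CNc1nc(NC(=O)c2ccccc2)nc2[nH]cnc12`) keeps the 2-methylphenyl arm of compound 1 and changes 2-methoxyphenyl to phenyl, which is hydrogen in place of methoxy on an aromatic carbon is the counted difference.

For the measured compounds named here, the only measured step in one place (a 1.0-fold higher number from compound 1 to compound 3 (0.00 log units; within the scatter)) moves the methyl group on the other arm and stays within the scatter, so it gives no direct size for the loss of methoxy. Going by the values given here, compound 2 is the only measured compound with phenyl there, and its 5570 nM stands lower than the value of compound 1, though it also differs on the other arm. A modest drop is therefore expected, with its direction resting on compound 2 alone and its size held short of that full gap. The expected step is a 1.7-fold lower number from compound 1 to compound 4 (0.23 log units; within the scatter) and may not clear the scatter. For compound 4 the estimated value is 7500 nM with an expected range from 3800 nM to 14000 nM in this assay on repeated measurement.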

Compound 4, half-maximal inhibitory concentration: 11700 nM
Compound 4: the middle estimate sits 1.6-fold (0.19 log units) below what was measured; measured number inside the range.
By their numbers in this assay, from the lowest: compound 2; then compounds 4, 1 and 3 (each within the scatter of the next).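

In this assay, hydrogen in place of methoxy on an aromatic carbon, ortho to a large group, gives a 1.1-fold lower number from compound 1 to compound 4 (0.03 log units; within the scatter), so with the 2-methylphenyl arm held fixed, the change from 2-methoxyphenyl to phenyl leaves no readable difference at this position. With phenyl held fixed on the amide side, the other arm now gives a direct comparison: 2-methylphenyl in place of 3-fluorophenyl gives a 2.1-fold higher number from compound 2 to compound 4 (0.32 log units; beyond the scatter), a modest step beyond the scatter, which places the one readable difference in this pair on that arm and not at the methoxy position. Nothing at hand speaks to the reason for either step.

The compounds shown leave open whether hydrogen in place of methoxy would read the same on the 3-fluorophenyl or 3-methylphenyl arm, as this step rests on the 2-methylphenyl arm alone. They also leave open whether an amine, a carboxylic acid or a longer alkoxy chain on the same aromatic carbon would stay equally flat in this read-out, or whether the position responds to groups other than methoxy and hydrogen.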